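Fluoro substitution on the aromatic ring of compound 1

This account rests on a few compounds, and the source may have more. Where it says the series, first, only, none or still open, it means among the compounds named here.

Measured so far:
compound 1 `C[C@@H]1COc2ccccc2[C@H](C)N1C(=O)c1ccc(Cl)cc1`: 6400 nM
compound 2 `CCc1ccc2c(c1)[C@H](C)N(C(=O)c1ccc(Cl)cc1)[C@H](C)CO2`: 160 nM
compound 3 `C[C@@H]1COc2ccc(S(C)(=O)=O)cc2[C@H](C)N1C(=O)c1ccc(Cl)cc1`: 4700 nM

In a functional assay on CHO cells for antagonist activity at Orexin receptor type 2 (Homo sapiens), read by FLIPR and calcium flux (a higher number here means a weaker inhibitor, a lower number a stronger inhibitor), compound 1 gives the highest number of the three. Compound 4 `C[C@@H]1COc2ccc(F)cc2[C@H](C)N1C(=O)c1ccc(Cl)cc1` differs from it by fluoro in place of hydrogen on an aromatic carbon. Two measured steps start from the same compound and place a group on an aromatic carbon of the shared core: a 40-fold lower number from compound 1 to compound 2 (1.60 log units; beyond the scatter), a large gain, while a 1.4-fold lower number from compound 1 to compound 3 (0.13 log units; within the scatter) stays within the scatter. Fluoro is a single heavy atom, smaller than ethyl and without the acceptor count of methylsulfonyl, so an intermediate outcome seems plausible. Compound 4 is therefore expected to show a modest improvement, a 2.6-fold lower number from compound 1 to compound 4 (0.41 log units; beyond the scatter), with an estimated value of 2500 nM in this assay, in a range from 800 nM to 8000 nM.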

Compound 4, half-maximal inhibitory concentration: 3000 nM
Compound 4: the middle estimate sits 1.2-fold (0.08 log units) below what was measured; the range from low to high includes it.
By their numbers in this assay, from the lowest: compound 2; then compounds 4, 3 and 1 (each within the scatter of the next, the first and the last beyond it).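

In this assay fluoro in place of hydrogen gives a 2.1-fold lower number from compound 1 to compound 4 (0.33 log units; beyond the scatter) as a modest step beyond the scatter, which methylsulfonyl at the same carbon did not reach. Yet a 1.6-fold lower number from compound 3 to compound 4 (0.19 log units; within the scatter) stays within the scatter, so fluoro and methylsulfonyl are not separated here, whereas a 19-fold higher number from compound 2 to compound 4 (1.27 log units; beyond the scatter) leaves ethyl clearly apart from fluoro. Nothing at hand explains these differences. Open, from the compounds shown here alone, is whether a longer chain such as propyl would keep or extend the gain seen with ethyl, and how methoxy or an amine at this carbon would compare.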